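The source may report more compounds than this note shows. Statements on the series, on what has been measured and on what is new or still open speak of the compounds shown alone.

Compound 1, whose structure is `CCc1ccc(NC2=CC(=O)c3c(nc4n3[C@H]3OC[C@@H](O)[C@H]3OC4)C2=O)cc1`, was tested in a functional assay on MCF7 cells (Homo sapiens) for inhibition, read by sulforhodamine B assay (a lower number here means a stronger inhibitor, a higher number a weaker inhibitor), and gave 8990 nM. Of the two numbers recorded, compound 1 stands highest: its partner compound 2, with the structure `CCc1ccc(NC2=CC(=O)c3nc4n(c3C2=O)[C@H]2OC[C@@H](O)[C@H]2OC4)cc1`, gave 960 nM in this assay, a lower number that lies beyond the usual scatter of such measurements. Among the compounds with values here, no single-point step between measured compounds is available, so nothing yet shows how changes on the aryl group move the readings.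

Compound 3, with the structure `CCOc1ccccc1NC1=CC(=O)c2c(nc3n2[C@H]2OC[C@@H](O)[C@H]2OC3)C1=O`, differs from compound 1 in one place: 2-ethoxyphenyl in place of 4-ethylphenyl on an amine nitrogen. Without a measured step of this kind to lean on, the expectation for compound 3 is a change from compound 1 of no more than the scatter in either direction, and the step from compound 1 to compound 3 is estimated at a 1.0-fold higher number from compound 1 to compound 3 (0.00 log units; within the scatter). Compound 3 is therefore expected to give about 9000 nM in this assay, within a range from 2500 nM to 32000 nM.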

Compound 3, half-maximal inhibitory concentration: > 4000 nM
Compound 3 ended at the assay's limit; the forecaster's own chance of this, stated with the estimate: 10%; the middle value does not contradict the limit.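

In this assay compound 3 gave > 4000 nM, which is a limit of the assay and not a number, so the step between compound 1 and compound 3 cannot be read. On these data alone, whether 2-ethoxyphenyl in place of 4-ethylphenyl raises or lowers the number stays open.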